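Thioether side chain variation on the shared core

This account rests on a few compounds, and the source may have more. Where it says the series, first, only, none or still open, it means among the compounds named here.

Compound 3 `N#Cc1c(N)nc(SCc2ccn[nH]2)c(C#N)c1-c1ccc(OCC2CC2)cc1` carries a 1H-pyrazol-5-yl group on a saturated chain carbon bound to a sulfur. Among the compounds with values here, in an assay on CHO cells for displacement of a labelled ligand from adenosine receptor A3 (Homo sapiens), read by scintillation counting, with a stated time of 120 min, tested at 1 uM (a higher number here means more inhibition at the concentration tested (going by the name of the read-out), a lower number less inhibition), compound 3 gives 6%, the lowest of the three numbers so far. Compound 1 `N#Cc1c(N)nc(SCC(N)=O)c(C#N)c1-c1ccc(OCC2CC2)cc1` stands nearest, as compound 1 gives 8%; the step of a number 2 percentage points lower from compound 1 to compound 3 (within the scatter). Compound 2 `N#Cc1c(N)nc(SCc2cccnc2)c(C#N)c1-c1ccc(OCC2CC2)cc1` lies furthest, since compound 2 gives 19%; the step of a number 13 percentage points lower from compound 2 to compound 3 (beyond the scatter), and the step of a number 11 percentage points higher from compound 1 to compound 2 (beyond the scatter).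

Compound 4 `N#Cc1c(N)nc(SCC(=O)NCO)c(C#N)c1-c1ccc(OCC2CC2)cc1` is not yet measured. Its change from compound 3: (hydroxymethyl)carbamoyl in place of 1H-pyrazol-5-yl on a saturated chain carbon bound to a sulfur. Within the data shown here, of the measured steps, the one between compound 1 and compound 3 bears most directly on this change, because compound 1 already holds a carbamoyl group on a saturated chain carbon bound to a sulfur and the step of a number 2 percentage points lower from compound 1 to compound 3 (within the scatter) stayed within the scatter. Among the measured compounds shown here, compound 4 carries a (hydroxymethyl)carbamoyl group at that place instead of a plain carbamoyl, and no measured pair shows what such an extension does. The expectation is therefore a number close to that of compound 1, which means for compound 4 an estimated step of a number 2 percentage points higher from compound 3 to compound 4 (within the scatter) that stays within the scatter. Compound 4 is expected to give about 8%, in the range from -4% to 20%.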

Compound 4, a percentage reported as inhibition, at one concentration (the size of the read-out at that concentration, not a potency): 8%
Compound 4: the middle estimate sits on the measured number at the digits printed; measured number inside the range.
By their numbers in this assay, from the lowest: compounds 3, 1 and 4 (each within the scatter of the next); then compound 2.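

In this assay, within the data shown here, hydroxymethyl in place of hydrogen on an amide-type nitrogen gives the first reading on an extension of the carbamoyl group, with no change at the digits printed from compound 1 to compound 4 (within the scatter) for that single change. The ringless (hydroxymethyl)carbamoyl group also stays level with the 1H-pyrazol-5-yl group, with a number 2 percentage points higher from compound 3 to compound 4 (within the scatter) at this place on a saturated chain carbon bound to a sulfur. Against pyridin-3-yl the picture differs, with a number 11 percentage points lower from compound 2 to compound 4 (beyond the scatter) in the same series, so compound 2 alone stands apart among the four while the others remain within the scatter of one another. No measured evidence here accounts for any of these readings.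

As far as these compounds go, it remains open whether the higher number of compound 2 at 19% belongs to pyridin-3-yl specifically or would also appear with a phenyl ring or a pyridin-4-yl group at this place. Also open, from the compounds shown here alone, is what a carboxylic acid or a primary amine at this place, or a longer chain on the amide-type nitrogen, would give in this read-out.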